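Replacing the piperazin-1-yl group of compound 2

The compounds below may be only part of what the source reports. "The series", "measured", "known", "first", "only" and "open" are said of these compounds alone.

In a functional assay on K562 cells (Homo sapiens) for cytotoxicity, read by fluorescence, with a stated time of 72 h (a lower number here means a stronger inhibitor, a higher number a weaker inhibitor), compound 2 `CC(C)c1n[nH]c2c(NCc3ccc(-c4ccccn4)cc3)nc(N3CCNCC3)nc12` gives 17 nM, the lower of the two numbers available, and compound 1 `CC(C)c1n[nH]c2c(NCc3ccc(-c4ccccn4)cc3)nc(N3CCCCC3CCO)nc12` gives 165 nM. Compound 3 `CC(C)c1n[nH]c2c(NCc3ccc(-c4ccccn4)cc3)nc(N[C@H]3CC[C@H](N)CC3)nc12`, not yet measured, carries (4-aminocyclohexyl)amino in place of piperazin-1-yl on the aromatic carbon between two ring nitrogen atoms: (4-aminocyclohexyl)amino in place of piperazin-1-yl on an aromatic carbon. Going by the values given here, the only measured step at this place is a 9.7-fold lower number from compound 1 to compound 2 (0.99 log units; beyond the scatter), which put piperazin-1-yl in place of 2-(2-hydroxyethyl)piperidin-1-yl and lies beyond the scatter. That step shows that the number in this assay can move with the group here. Among the compounds with values here, no measured compound carries the entering group, however, so the data offer no direction for the new change. The expected result is therefore a 1.1-fold lower number from compound 2 to compound 3 (0.05 log units; within the scatter), with no shift beyond the scatter anticipated. For compound 3 the estimated value is 15 nM, within an expected range of 5 nM to 50 nM.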

Compound 3, half-maximal inhibitory concentration: 593 nM
Compound 3: the middle estimate sits 40-fold (1.60 log units) below what was measured; the measured number lies above the stated range.
By their numbers in this assay, from the lowest: compound 2; then compound 1; then compound 3.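

In this assay, the group at this place does more than tune the number: a 35-fold higher number from compound 2 to compound 3 (1.54 log units; beyond the scatter), so a six-membered non-aromatic ring with 2 nitrogen atoms in the group is not enough to keep the low number of compound 2. The same change also falls short of the earlier, weaker group, with a 3.6-fold higher number from compound 1 to compound 3 (0.56 log units; beyond the scatter), which makes compound 3 the weakest of the three. Nothing available explains these differences in the cell assay.

The compounds shown do not separate the effect of replacing the ring nitrogen with carbon from that of attaching the ring through an amino link. They also leave open how 4-methylpiperazin-1-yl or an open-chain 2-aminoethylamino group would compare at this place.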